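The source may report more compounds than this note shows. Statements on the series, on what has been measured and on what is new or still open speak of the compounds shown alone.

Compound 1 `c1ccc(CNc2nnc(-c3c[nH]c4ncccc34)o2)cc1` is the reference point: in an ADME assay (liver) for metabolic stability, with Liver microsome (Homo sapiens) as the target, using microsomes (on this read-out higher numbers stand for fast clearance and lower numbers for slow clearance), compound 1 gives 31 mL.min-1.g-1. Compound 2 `Fc1cccc(CNc2nnc(-c3c[nH]c4ncccc34)o2)c1` carries fluoro in place of hydrogen on an aromatic carbon, and in this assay compound 2 gives 54 mL.min-1.g-1, a step of a 1.7-fold higher number from compound 1 to compound 2 (0.24 log units; within the scatter). Compound 3 `Fc1ncccc1[C@H](Nc1nnc(-c2c[nH]c3ncccc23)o1)C1CC1` differs from compound 1 in its core, a difference that is not broken down here; in this assay compound 3 gives 21 mL.min-1.g-1. Compound 4 `Fc1ccc2c(-c3nnc(N[C@@H](c4cccnc4F)C4CC4)o3)c[nH]c2n1` is not yet measured and carries fluoro in place of hydrogen on an aromatic carbon. This is the same kind of change as the earlier one, though the place differs: there the fluoro sat on a six-membered aromatic ring of carbon only, meta to a large group, whereas here it sits on a six-membered aromatic ring with 1 nitrogen, part of a fused or bridged system of two rings, next to the ring nitrogen, meta to a fused ring and para to a fused ring. On the strength of a 1.7-fold higher number from compound 1 to compound 2 (0.24 log units; within the scatter), the step is expected to be a 1.4-fold higher number from compound 3 to compound 4 (0.15 log units; within the scatter). Compound 4 is therefore estimated at 30 mL.min-1.g-1 in this assay, expected to fall between 15 mL.min-1.g-1 and 60 mL.min-1.g-1.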

Compound 4, intrinsic clearance in microsomes: < 14 mL.min-1.g-1
Compound 4 gave a limit, no number (the forecaster's own chance of this, stated with the estimate: 5%); middle value at least 2.1-fold (0.33 log units) from the limit.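

In this assay compound 4 gives < 14 mL.min-1.g-1 as a limit of the assay, not a number. Fluoro in place of hydrogen on an aromatic carbon brings an at least 1.5-fold lower number from compound 3 to compound 4 (0.17 log units; that floor lies within the scatter) here, and the comparison with the earlier step stays unsettled: the same change on two cores in this assay, a 1.7-fold higher number (0.24 log units; within the scatter) from compound 1 to compound 2 and an at least 1.5-fold lower number (0.17 log units; that floor lies within the scatter) from compound 3 to compound 4; the limit leaves it open whether they differ. The data therefore show neither that the earlier step carries over to this core nor that it fails to, and the fluoro sits in a different place on each core.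

The compounds shown leave open what number lies behind the limit of compound 4. They also leave open whether a chloro or a methyl group in that same place would behave as the fluoro does.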